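Urea in place of amide on the shared core

The source may hold more compounds than are shown below. What is called first, only, known or untested is meant among the compounds shown, and "the series" means these compounds.

Compound 2 `COc1cc(-c2nn(-c3cccc(NC(=O)c4cccc(C(F)(F)F)c4)c3)cc2-c2ccncc2)ccc1Cl` is the weaker of the two measured compounds: in a functional assay on KM12 cells (Homo sapiens) for inhibition, read by sulforhodamine B assay, with a stated time of 48 h (on this read-out higher numbers stand for weaker inhibition and lower numbers for stronger inhibition), compound 2 gives 1660 nM, while compound 1 `COc1cc(-c2nn(-c3cccc(NC(=O)Nc4cc(C(F)(F)F)cc(C(F)(F)F)c4)c3)cc2-c2ccncc2)ccc1Cl` gives 530 nM, a difference beyond the scatter. Compound 3 `COc1cc(-c2nn(-c3cccc(NC(=O)Nc4ccc(Cl)c(Cl)c4)c3)cc2-c2ccncc2)ccc1Cl` differs from compound 2 by (3,4-dichlorophenyl)amino in place of 3-(trifluoromethyl)phenyl on a carbonyl carbon. Compound 3 is expected to move toward stronger inhibition, by about a 3.0-fold lower number from compound 2 to compound 3 (0.48 log units; beyond the scatter), because compound 1 gives 530 nM and likewise carries a carbamoyl link. The estimate for compound 3 in this assay is 550 nM, with a likely range from 150 nM to 2000 nM.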

Compound 3, half-maximal inhibitory concentration: 810 nM
Compound 3: middle estimate off by 1.5-fold (0.17 log units), on the low side; the range from low to high includes it.
By their numbers in this assay, from the lowest: compounds 1 and 3 (each within the scatter of the next); then compound 2.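

The step of a 2.0-fold lower number from compound 2 to compound 3 (0.31 log units; beyond the scatter) shows that this carbonyl position tolerates a swap of the whole aryl side, with (3,4-dichlorophenyl)amino giving a modest gain over 3-(trifluoromethyl)phenyl. Compound 1 at 530 nM and compound 3 at 810 nM lie within the scatter of each other, so two differently substituted carbamoyl compounds give matching numbers. The step changes both the amino link and the ring substituents, so the two contributions remain unseparated; a (3-(trifluoromethyl)phenyl)amino group on the same carbonyl carbon would divide them. No measurement shown here explains the step.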